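Propyl to Isobutyl on a Shared Core

This account rests on a few compounds, and the source may have more. Where it says the series, first, only, none or still open, it means among the compounds named here.

Of the compounds shown here, three have been measured in a functional assay on HTB-54 cells (Homo sapiens) for cytotoxicity, read by MTT assay, with a stated time of 72 h; a lower number here means a stronger inhibitor of growth, a higher number a weaker inhibitor of growth. Compound 1 `COc1ccc(OC(=O)Nc2ccc([Se]C#N)cc2)cc1` gives 48500 nM. Compound 2 `CCCOC(=O)Nc1ccc([Se]C#N)cc1` gives 51900 nM, and compound 3 `CCOC(=O)Nc1ccc([Se][Se]c2ccc(NC(=O)OCC)cc2)cc1` gives 56600 nM. Among these three numbers compound 2 holds the second highest; its nearest neighbour is compound 1 and its furthest is compound 3, and both gaps fall within the scatter of repeated measurements, so the three compounds cannot be told apart on these numbers.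

Compound 4 `CC(C)COC(=O)Nc1ccc([Se]C#N)cc1` has not yet been measured. It differs from compound 2 by a single change: methyl in place of hydrogen on a saturated chain carbon bound to two saturated chain carbons, so the propyl chain of compound 2 becomes an isobutyl chain. Among the measured compounds shown here, no measured pair in this set shows what such a change does, so no measured step can be borrowed. With the three measured numbers all sitting together, the change is expected to produce no step beyond the scatter in either direction. The expected step of a 1.0-fold lower number from compound 2 to compound 4 (0.02 log units; within the scatter) is therefore small. Compound 4 is estimated at 50000 nM, with a likely range from 25000 nM to 100000 nM.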

Compound 4, concentration for total growth inhibition: 51200 nM
For compound 4 the middle estimate is 1.0-fold (0.01 log units) below the measured one; measured number inside the range.
By their numbers in this assay, from the lowest: compounds 1, 4, 2 and 3 (each within the scatter of the next).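

In this assay, among the compounds shown here, the change of propyl to isobutyl gives a 1.0-fold lower number from compound 2 to compound 4 (0.01 log units; within the scatter), and this is the first pair in the set that differs in only one place. For the compounds shown here, it shows directly that methyl in place of hydrogen on this saturated chain carbon leaves compound 2 and compound 4 indistinguishable in this assay, whereas the earlier compounds could only be compared across several differences at once. Nothing measured on these compounds offers an explanation for this result.

Still open, going by these compounds, is whether a longer chain, such as hexyl, or a chain ending in an amine or a carboxylic acid would shift the number beyond the scatter. A single pair also cannot show whether the same methyl would behave alike on a different core.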